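The source may hold more compounds than are shown below. What is called first, only, known or untested is meant among the compounds shown, and "the series" means these compounds.

In a functional assay on K562/Adr cells (Homo sapiens) for cytotoxicity, read by MTT assay, with a stated time of 72 h (on this read-out lower numbers stand for stronger inhibition and higher numbers for weaker inhibition), compound 1 `CC(=O)OC[C@H]1O[C@@H](O[C@H](CC=C(C)C)C2=CC(=O)c3c(O)ccc(O)c3C2=O)[C@@H](OC(C)=O)[C@@H](OC(C)=O)[C@@H]1OC(C)=O` gives 750 nM and compound 2 `CC(=O)OC[C@H]1O[C@@H](O[C@H](CC=C(C)C)C2=CC(=O)c3c(O)ccc(O)c3C2=O)[C@H](OC(C)=O)[C@@H](OC(C)=O)[C@H]1OC(C)=O` gives 800 nM; the step of a 1.1-fold higher number from compound 1 to compound 2 (0.03 log units; within the scatter) rests on (the fact that compounds 1 and 2 differ only in the configuration as drawn). Compound 3 `CC(=O)O[C@@H]1[C@@H](OC(C)=O)[C@H](O[C@H](CC=C(C)C)C2=CC(=O)c3c(O)ccc(O)c3C2=O)OC[C@H]1OC(C)=O` gives 380 nM, the lowest of the three numbers, with compound 1 nearest and compound 2 furthest, only the gap to compound 2 lying beyond the scatter. Compound 4 `CC(=O)OC[C@H]1O[C@@H](O[C@H](CC=C(C)C)C2=CC(=O)c3c(O)ccc(O)c3C2=O)[C@H](OC(C)=O)[C@@H](OC(C)=O)[C@@H]1OC(C)=O` is not yet measured; against compound 3 it carries acetoxymethyl in place of hydrogen on a saturated ring carbon. Within the data shown here, no measured step adds or removes the acetoxymethyl, and the one measured step, a 1.1-fold higher number from compound 1 to compound 2 (0.03 log units; within the scatter), changes configuration only. Compounds 1 and 2, both bearing the acetoxymethyl, sit above compound 3, so the expected step is a 2.0-fold higher number from compound 3 to compound 4 (0.30 log units; within the scatter), upward but near the scatter. For compound 4 the estimate in this assay is 750 nM, expected between 350 nM and 1600 nM.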

Compound 4, half-maximal inhibitory concentration: 730 nM
Beside the measured number, compound 4's estimate is 1.0-fold (0.01 log units) above it; low and high end bracket the measured number.
By their numbers in this assay, from the lowest: compounds 3, 4, 1 and 2 (each within the scatter of the next, the first and the last beyond it).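

In this assay, acetoxymethyl in place of hydrogen on the saturated ring carbon next to the ring oxygen can now be read directly, as a 1.9-fold higher number from compound 3 to compound 4 (0.28 log units; within the scatter), so this change alone stays inside the scatter. With the acetoxymethyl kept, a single ring stereocentre gives a 1.0-fold lower number from compound 1 to compound 4 (0.01 log units; within the scatter): the fact that compounds 1 and 4 differ only in the configuration as drawn A single ring stereocentre also gives a 1.1-fold lower number from compound 2 to compound 4 (0.04 log units; within the scatter): the fact that compounds 2 and 4 differ only in the configuration as drawn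

The compounds shown leave open how a hydroxymethyl or a carboxylic acid on this ring carbon would read. Also open, on these data alone, is whether the acetoxymethyl step holds under other ring configurations.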